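A few compounds are considered here, and "the series" means these few. Any claim that something is new, unique, unknown or untested is made for them only; others in the source may bear on it.

Compound 1 `O=C(O)CC(NS(=O)(=O)c1ccc(C(F)(F)F)cc1)c1ccccc1`: 54700 nM
Compound 2 `O=C(O)CC(NS(=O)(=O)c1ccccc1)c1ccccc1F`: > 100000 nM, a limit of the assay
Compound 3 `N#Cc1ccc(S(=O)(=O)NC(CC(=O)O)c2ccccc2F)cc1`: 77700 nM

In a functional assay on MDA-MB-436 cells (Homo sapiens) for antiproliferative activity, read by MTT assay, with a stated time of 24 h (a higher number here means a weaker inhibitor, a lower number a stronger inhibitor), compound 3 gives 77700 nM, and this lies within the scatter of compound 1. The value of compound 2, > 100000 nM, is a limit.

Compound 4 `O=C(O)CC(NS(=O)(=O)c1ccc(C(F)(F)F)cc1)c1ccccc1F` differs from compound 3 by one change, trifluoromethyl in place of cyano on an aromatic carbon, para to a large group: trifluoromethyl in place of cyano on an aromatic carbon. Going by the values given here, no measured step makes this exchange directly. The nearest is an at least 1.2-fold lower number from compound 2 to compound 3 (0.10 log units; that floor lies within the scatter), with cyano in place of hydrogen on an aromatic carbon, and it shows nothing beyond the scatter. Compound 1 also carries trifluoromethyl and gives 54700 nM, so a large shift is not expected from that group. In this assay, the expected size is a 1.3-fold lower number from compound 3 to compound 4 (0.11 log units; within the scatter), which amounts to no step beyond the scatter. A result at the limit remains possible, given (the limit of > 100000 nM in this assay, at which 1 of the 3 values shown sits). For compound 4 the estimate is 60000 nM, with an expected range from 30000 nM to 100000 nM.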

Compound 4, half-maximal inhibitory concentration: 55600 nM
Estimate against measurement, compound 4: 1.1-fold (0.03 log units) above; the measured number falls inside the stated range.
By their numbers in this assay, from the lowest: compounds 1, 4 and 3 (each within the scatter of the next). At a limit, above all of these: compound 2.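

In this assay, the exchange on this aromatic carbon, para to a large group, now has a direct reading: a 1.4-fold lower number from compound 3 to compound 4 (0.15 log units; within the scatter) is within the scatter, so trifluoromethyl and cyano cannot be told apart here. Going by these compounds alone, the fluoro exchange can also be read directly for the first time, and a 1.0-fold higher number from compound 1 to compound 4 (0.01 log units; within the scatter) likewise stays within the scatter. With hydrogen at the same position the reading is an at least 1.7-fold lower number from compound 2 to compound 4 (0.25 log units; that floor lies within the scatter) and gives only a floor within the scatter, since the value of compound 2 is a limit: the limit of > 100000 nM in this assay, at which 1 of the 4 values shown sits.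

The compounds shown leave open whether an amine or a methoxy group at this position would move the number beyond the scatter. They also leave open whether an ester in place of the carboxylic acid would do so.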